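A few compounds are considered here, and "the series" means these few. Any claim that something is new, unique, unknown or untested is made for them only; others in the source may bear on it.

Measured so far in a functional assay on A-431 cells (Homo sapiens) for antiproliferative activity, read by MTT assay, with a stated time of 72 h; a lower number here means a stronger inhibitor, a higher number a weaker inhibitor:
compound 1 `COc1cc2ncnc(Nc3cccc(C(F)(F)F)c3)c2cc1OCCCN1CCNCCNCCNCC1`: 1950 nM
compound 2 `COc1cc2ncnc(Nc3cccc(F)c3)c2cc1OCCCN1CCNCCNCCNCC1`: 1860 nM
compound 3 `CCc1cc(Br)ccc1Nc1ncnc2cc(OC)c(OCCCN3CCNCCNCCNCC3)cc12`: 5650 nM

Compound 3 gives the highest number of the three: the step of a 2.9-fold higher number from compound 1 to compound 3 (0.46 log units; beyond the scatter) and the step of a 3.0-fold higher number from compound 2 to compound 3 (0.48 log units; beyond the scatter) both lie beyond the scatter, whereas a 1.0-fold lower number from compound 1 to compound 2 (0.02 log units; within the scatter) is within it. Compound 4 `CCc1cc(Br)ccc1Nc1ncnc2cc(OC)c(OCCCN3CCNCCNCC3)cc12` differs from compound 3 elsewhere in the molecule: a group of 9 heavy atoms (6 carbon, 3 nitrogen; one nine-membered non-aromatic ring with 3 hetero atoms) in place of a group of 12 heavy atoms (8 carbon, 4 nitrogen; one twelve-membered non-aromatic ring with 4 hetero atoms), on a saturated chain carbon, three bonds along the chain from an oxygen on an aromatic ring. Going by the values given here, none of the measured steps touches this chain-borne ring; all three vary only the aryl group on the nitrogen attached to the shared core. Among the compounds with values here, nothing among the measured compounds therefore anchors the size or direction of this step in this assay, and the working expectation is a step no larger than the scatter, a 1.1-fold higher number from compound 3 to compound 4 (0.03 log units; within the scatter), with a wide range. Compound 4 is estimated at 6000 nM in this assay, range 2000 nM to 18000 nM.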

Compound 4, half-maximal inhibitory concentration: 18800 nM
Compound 4: middle estimate off by 3.1-fold (0.50 log units), on the low side; measured number outside the range, above it.
By their numbers in this assay, from the lowest: compounds 2 and 1 (each within the scatter of the next); then compound 3; then compound 4.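

In this assay, the chain-borne ring is not a neutral position: the nine-membered ring with 3 hetero atoms in place of the larger ring with 4 hetero atoms gives a 3.3-fold higher number from compound 3 to compound 4 (0.52 log units; beyond the scatter), a step beyond the scatter. Activity in this series therefore depends on this ring as well as on the aryl group on the nitrogen, though the ring change is seen only with 4-bromo-2-ethylphenyl. No measurement here accounts for the step.

Still open, on these data alone, is whether the step holds with 3-fluorophenyl or 3-(trifluoromethyl)phenyl on that nitrogen. As far as these compounds go, how a piperazine or a dimethylamine in the same place would compare also remains open.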